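The source may report more compounds than this note shows. Statements on the series, on what has been measured and on what is new or still open speak of the compounds shown alone.

Measured compounds:
Compound 1, `COc1ccc(C(=O)c2c(N)sc3c2CCC3)c2ccccc12`, in an assay on isolated protein with adenosine receptor A3 (Homo sapiens) as the target, tested at 10 uM (a lower number here means less inhibition, a higher number more inhibition at the concentration tested (going by the name of the read-out)), gives 57%.
Compound 2, `Nc1sc2c(c1C(=O)c1ccc(Cl)c3ccccc13)CCC2`, in this assay gives 0%.

Compound 2 stands lowest of the two numbers in this assay. Going by the values given here, its only neighbour is compound 1, and the step of a number 57 percentage points lower from compound 1 to compound 2 (beyond the scatter) separates the two, a large step that lies beyond the scatter. That step is the sole measured one in the set and corresponds to chloro in place of methoxy on an aromatic carbon.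

Compound 3, `Nc1sc2c(c1C(=O)c1ccc(Br)c3ccccc13)CCC2`, has not yet been measured in this assay. It differs from compound 2 by bromo in place of chloro on an aromatic carbon. Among the compounds with values here, no measured step exchanges one halogen for another, so the step of a number 57 percentage points lower from compound 1 to compound 2 (beyond the scatter) speaks to a different exchange and bears on this one only loosely: it shows that the chloro compound sits at the bottom of the range, which leaves little room for a further fall. For compound 3 the step of a number 5 percentage points higher from compound 2 to compound 3 (within the scatter) is expected to stay within the scatter, with no direction beyond it. Compound 3 is therefore estimated at 5%, in a range from 0% to 25%.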

Compound 3, a percentage reported as inhibition, at one concentration (the size of the read-out at that concentration, not a potency): 22%
Compound 3: the middle estimate sits 17 percentage points below what was measured, and the stated range covers the measured number.
By their numbers in this assay, from the lowest: compound 2; then compound 3; then compound 1.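

In this assay, this aromatic carbon, para to a large group, proves sensitive even to an exchange of one halogen for another: bromo in place of chloro gives a number 22 percentage points higher from compound 2 to compound 3 (beyond the scatter), so compound 2 and its bromo partner cannot be treated as equivalent here, something the earlier pair could not show. Methoxy still stands apart from both halogens, with bromo in its place giving a number 35 percentage points lower from compound 1 to compound 3 (beyond the scatter), and the three compounds run from the lowest as compound 2, then compound 3, then compound 1, which places the bromo compound between the other two rather than at the bottom of the range. Nothing available with these numbers accounts for the difference between the two halogens.

The compounds shown leave open how fluoro, iodo, methyl, ethoxy or an amine on the same carbon would compare with chloro, bromo and methoxy, and so whether the order seen here extends to other groups. Each number is also a reading at one concentration, and whether the same order would hold for potency remains unsettled.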